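This account rests on a few compounds, and the source may have more. Where it says the series, first, only, none or still open, it means among the compounds named here.

Compound 1 `COc1ccc(CN2C(=O)C(=O)c3ccc(-c4ccc(OC)cc4)cc32)cc1`: > 10000 nM 
Compound 2 `COc1ccc(CN2C(=O)C(=O)c3cc(-c4ccc(OC)c(OC)c4)ccc32)cc1`: > 10000 nM 

In a functional assay on HepG2 cells (Homo sapiens) for antiproliferative activity, read by MTT assay, with a stated time of 48 h (on this read-out lower numbers stand for stronger inhibition and higher numbers for weaker inhibition), compound 2 reaches only a limit, not a number, with > 10000 nM. In this assay compound 1 likewise gives a limit, > 10000 nM. Both measured values are limits, (the limit of > 10000 nM in this assay, at which 2 of the 2 values shown sit). Compound 3 `COc1ccc(CN2C(=O)C(=O)c3cc(-c4ccc(C#N)cc4)ccc32)cc1` carries 4-cyanophenyl in place of 3,4-dimethoxyphenyl on an aromatic carbon. For the measured compounds named here, no measured step exists for this exchange, so the expected step is a step that the limit leaves unreadable from compound 2 to compound 3, not clearly beyond the scatter in either direction. Compound 3 is therefore estimated to give 15000 nM, within a range from 3000 nM to 60000 nM.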

Compound 3, half-maximal inhibitory concentration: 890 nM
For compound 3 the middle estimate is 17-fold (1.23 log units) above the measured one; measured number below the stated range.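

In this assay, for the compounds shown here, putting 4-cyanophenyl in place of 3,4-dimethoxyphenyl gives an at least 11-fold lower number from compound 2 to compound 3 (1.05 log units; beyond the scatter), and compound 3 is the first compound here with a real number rather than a limit. This aromatic carbon of the shared core is therefore a place where the attached group can change the result strongly. The full size of the step stays unknown, since its starting point is only a limit: the limit of > 10000 nM in this assay, at which 2 of the 3 values shown sit.

Going by these compounds, it remains open whether the nitrile itself or the loss of the two methoxy groups matters more. On these data alone, how an amine or a carboxylic acid on that phenyl ring would read out also remains open.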